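Removing one ring hydroxy from compound 3

The source may hold more compounds than are shown below. What is called first, only, known or untested is meant among the compounds shown, and "the series" means these compounds.

compound 1 `CCN(CC)Cc1c(O)c([C@H]2CCN(C)C[C@H]2O)c2oc(C)cc(=O)c2c1O` gives 24%
compound 2 `Cc1cc(=O)c2c(O)c(CN3CCCC3CO)c(O)c([C@H]3CCN(C)C[C@H]3O)c2o1` gives 22%
compound 3 `Cc1cc(=O)c2c(O)c(CN3CC(O)CC3C(=O)O)c(O)c([C@H]3CCN(C)C[C@H]3O)c2o1` gives 25%

All three numbers come from a functional assay on MCF7 cells (Homo sapiens) for inhibition, read by MTT assay, with a stated time of 48 h, tested at 10 uM (a higher number here means more inhibition of growth at the concentration tested, a lower number less inhibition of growth), and sit within the usual scatter of one another. Compound 3 therefore stands level with the other two, with a number 1 percentage points higher from compound 1 to compound 3 (within the scatter) and a number 3 percentage points higher from compound 2 to compound 3 (within the scatter) as its measured steps.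

Compound 4 `Cc1cc(=O)c2c(O)c(CN3CCCC3C(=O)O)c(O)c([C@H]3CCN(C)C[C@H]3O)c2o1` differs from compound 3 in one place: hydrogen in place of hydroxy on a saturated ring carbon and in words, hydrogen in place of hydroxy on a saturated ring carbon. For the measured compounds named here, no measured pair isolates this hydroxy. The closest evidence comes from exchanging the whole amine group on the saturated chain carbon, which includes a number 2 percentage points lower from compound 1 to compound 2 (within the scatter) as well as the two steps to compound 3. Those exchanges change more of the structure than the hydroxy alone, yet none moved beyond the scatter. No step beyond the scatter is therefore expected in this assay for this smaller change. The estimated step is a number 1 percentage points lower from compound 3 to compound 4 (within the scatter) and its direction is not meaningful. In this assay compound 4 is estimated at 24% within an expected range of 14% to 34% as its upper end.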

Compound 4, percent growth inhibition at one concentration: 21%
Estimate against measurement, compound 4: 3 percentage points above, within the range that was stated.
By their numbers in this assay, from the lowest: compounds 4, 2, 1 and 3 (each within the scatter of the next).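

For the compounds shown here, with compound 4, this hydroxy on the saturated ring carbon, two ring bonds from the ring nitrogen, can be read on its own for the first time. In this assay, taking it away gives a number 4 percentage points lower from compound 3 to compound 4 (within the scatter), so this single change does not shift the reading beyond normal variation. Compound 4 also adds two further comparisons, carboxy in place of hydroxymethyl (a number 1 percentage points lower from compound 2 to compound 4 (within the scatter)) and 2-carboxypyrrolidin-1-yl in place of diethylamino (a number 3 percentage points lower from compound 1 to compound 4 (within the scatter)), and nothing measured here offers a reason for these results.

From the compounds shown here alone, whether a fluoro group in place of the hydroxy, or a methyl ester or primary amide in place of the carboxy, would behave the same remains open. Going by these compounds, all four compounds also share one core, so the effect of changes elsewhere, such as a longer chain in place of its methyl group, is unknown.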